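The source may hold more compounds than are shown below. What is called first, only, known or untested is meant among the compounds shown, and "the series" means these compounds.

Measured compounds and their values:

compound 1, `CNC(=O)c1cccc(Cn2nc(C)c(NC(=O)c3ccc(COc4ccccc4)cc3)c2C)c1`: 6200 nM
compound 2, `CNC(=O)c1cccc(Cn2nc(C)c(NC(=O)c3ccc(COc4cccc(C)c4)cc3)c2C)c1`: 6200 nM
compound 3, `CNC(=O)c1cccc(Cn2nc(C)c(NC(=O)c3ccc(COc4cccc(Cl)c4)cc3)c2C)c1`: 5900 nM

All three were tested in a functional assay on MIA PaCa-2 cells (Homo sapiens) for antiproliferative activity, read by MTT assay, with a stated time of 72 h; a higher number here means that more compound is needed for the effect, a lower number that less compound is needed. Compound 3 gives the lowest of the three numbers, but its nearest neighbour is compound 1, at a 1.1-fold lower number from compound 1 to compound 3 (0.02 log units; within the scatter), and its furthest is compound 2, at a 1.1-fold lower number from compound 2 to compound 3 (0.02 log units; within the scatter); both gaps lie within the scatter, so compound 3 cannot be set apart from the other two.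

Compound 4, `CNC(=O)c1cccc(Cn2nc(C)c(NC(=O)c3ccc(COc4ccccc4C(F)(F)F)cc3)c2C)c1`, has not yet been measured in this assay. Relative to compound 3 the change is 2-(trifluoromethyl)phenyl in place of 3-chlorophenyl on an oxygen on a saturated carbon.

Within the data shown here, the steps that bear on this are the three that alter the same phenoxy ring: no change at the digits printed from compound 1 to compound 2 (within the scatter), a 1.1-fold lower number from compound 1 to compound 3 (0.02 log units; within the scatter) and a 1.1-fold lower number from compound 2 to compound 3 (0.02 log units; within the scatter). None of them moves the number beyond the scatter, whether a hydrogen is replaced by methyl or by chloro, or methyl by chloro. On this basis the exchange of the 3-chlorophenyl for the 2-(trifluoromethyl)phenyl is expected to leave the number essentially where compound 3 sits, with no step beyond the scatter in either direction. This estimate corresponds to an expected step of a 1.0-fold higher number from compound 3 to compound 4 (0.01 log units; within the scatter). For compound 4 the expected value in this assay is 6000 nM, with a range from 3000 nM to 12000 nM.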

Compound 4, half-maximal effective concentration: 10000 nM
Compound 4: the middle estimate sits 1.7-fold (0.22 log units) below what was measured; measured number inside the range.
By their numbers in this assay, from the lowest: compounds 3, 1, 2 and 4 (each within the scatter of the next).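

In this assay the 2-(trifluoromethyl)phenyl on the oxygen on a saturated carbon cannot be set apart from any of the earlier rings, whether it is compared with the 3-chlorophenyl (a 1.7-fold higher number from compound 3 to compound 4 (0.23 log units; within the scatter)), the 3-methylphenyl (a 1.6-fold higher number from compound 2 to compound 4 (0.21 log units; within the scatter)) or the unsubstituted phenyl (a 1.6-fold higher number from compound 1 to compound 4 (0.21 log units; within the scatter)). The earlier compounds shown here showed this only for methyl and chloro, whereas this result extends it to trifluoromethyl, to a group of 10 heavy atoms entering where one of 7 leaves, and to a ring whose name carries its substituent at 2 and not at 3. All four compounds therefore stand together at this position, with no step among them beyond the scatter, and nothing available explains the numbers they give.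

The step from the 3-chlorophenyl to the 2-(trifluoromethyl)phenyl changes the group and its ring position at once, so the compounds shown cannot tell the two changes apart. They also leave open whether a ring bearing an amine or a carboxylic acid, or a longer chain in place of the saturated carbon, would move the number beyond the scatter.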